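Removing one trifluoromethyl from a diaryl urea

The source may report more compounds than this note shows. Statements on the series, on what has been measured and on what is new or still open speak of the compounds shown alone.

This account follows the pyrazole ureas and amides tested for cell toxicity. Compound 1 `O=C(Nc1cccc(-n2cc(-c3ccncc3)c(-c3ccc(Cl)c(O)c3)n2)c1)Nc1ccc(Cl)c(Cl)c1` in a functional assay on TK-10 cells (Homo sapiens) for inhibition, read by sulforhodamine B assay, with a stated time of 48 h (on this read-out lower numbers stand for higher toxicity in this test and higher numbers for lower toxicity in this test), gives only a limit, > 32500 nM. Compound 2 `COc1cc(-c2nn(-c3cccc(NC(=O)c4cccc(C(F)(F)F)c4)c3)cc2-c2ccncc2)ccc1Cl` gives a limit as well in this assay, > 50000 nM. Among the compounds with values here, compound 3 `O=C(Nc1cccc(-n2cc(-c3ccncc3)c(-c3ccc(Cl)c(O)c3)n2)c1)Nc1cc(C(F)(F)F)cc(C(F)(F)F)c1` is the one member with a number in this assay, 14200 nM. It therefore stands alone, since the other two values are limits (the limit of > 32500 nM in this assay, at which 1 of the 3 values shown sits, and (the limit of > 50000 nM in this assay, at which 1 of the 3 values shown sits)) rather than numbers.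

Compound 4 `O=C(Nc1cccc(-n2cc(-c3ccncc3)c(-c3ccc(Cl)c(O)c3)n2)c1)Nc1cccc(C(F)(F)F)c1` has not yet been measured in this assay. It differs from compound 3 in one place: hydrogen in place of trifluoromethyl on an aromatic carbon. Within the data shown here, no measured pair in this set differs in a single place, so no step size can be read from the data. Compound 4 is expected to be somewhat less toxic than compound 3, with a step of a 1.8-fold higher number from compound 3 to compound 4 (0.25 log units; within the scatter) that may well reach past the scatter, given that compound 1 gave only a limit, > 32500 nM. The estimate for compound 4 in this assay is 25000 nM, within a range from 9000 nM to 70000 nM.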

Compound 4, concentration lethal to 50% of the cells: > 32500 nM
Compound 4: only a limit was reported; the forecaster's own chance of this, stated with the estimate: 45%; at least 1.3-fold (0.11 log units) between middle value and limit.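

This pair gives the series its first readable step: in this assay, hydrogen in place of trifluoromethyl on an aromatic carbon gives an at least 2.2-fold higher number from compound 3 to compound 4 (0.35 log units; beyond the scatter), so the loss of this one group leaves compound 4 less toxic in this test. The earlier compounds shown here could not show this, since no two of them differed in a single place. The result for compound 4 is a limit, not a number, and it is one shared with another compound: the limit of > 32500 nM in this assay, at which 2 of the 4 values shown sit.

From the compounds shown here alone, how far the true value of compound 4 lies past that limit remains open, and the step from compound 1 to compound 4 cannot be read. Also open, going by these compounds, is where an amine or a methyl group on this aromatic carbon would fall in this assay.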